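This account rests on a few compounds, and the source may have more. Where it says the series, first, only, none or still open, it means among the compounds named here.

Working notes on the series around the shared core of compound 3 `Cc1ccc(NC(=O)NC(=O)c2ccc(OCc3cccc(Cl)c3)cc2)cc1-c1nc2ccccc2[nH]1`. In a functional assay on HT-29 cells (Homo sapiens) for inhibition, read by MTT assay, with a stated time of 48 h (on this read-out higher numbers stand for weaker inhibition and lower numbers for stronger inhibition), compound 3 gives 15400 nM, the lowest of the three numbers, though compound 2 `Cc1ccc(NC(=O)NC(=O)c2ccc(OCc3ccccc3)cc2)cc1-c1nc2ccccc2[nH]1` sits within the scatter of it: compound 2 gives 16400 nM, and the step of a 1.1-fold lower number from compound 2 to compound 3 (0.03 log units; within the scatter) is within the scatter. Compound 1 `Cc1ccc(NC(=S)NC(=O)c2ccc(OCc3cccc(Cl)c3Cl)cc2)cc1-c1nc2ccccc2[nH]1` gives 63700 nM, which lies beyond the scatter from compound 3.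

Compound 4 `Cc1ccc(NC(=O)NC(=O)c2ccc(OCc3ccc(C(F)(F)F)cc3)cc2)cc1-c1nc2ccccc2[nH]1` is not yet measured. The change from compound 3 is 4-(trifluoromethyl)phenyl in place of 3-chlorophenyl on a saturated chain carbon bound to an oxygen on an aromatic ring. Within the data shown here, only one measured step touches this part of the molecule, namely a 1.1-fold lower number from compound 2 to compound 3 (0.03 log units; within the scatter), and it was within the scatter. Among the measured compounds shown here, no measured step covers a trifluoromethyl group or a change of where a substituent sits on this ring, so there is no basis for expecting a shift in this assay beyond the scatter. The expected step is therefore a 1.1-fold lower number from compound 3 to compound 4 (0.04 log units; within the scatter), with a wide range to cover the untested group. For compound 4 the estimate in this assay is 14000 nM, expected to fall between 5000 nM and 40000 nM.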

Compound 4, half-maximal inhibitory concentration: 7830 nM
Compound 4: middle estimate off by 1.8-fold (0.25 log units), on the high side; low and high end bracket the measured number.
By their numbers in this assay, from the lowest: compounds 4, 3 and 2 (each within the scatter of the next, the first and the last beyond it); then compound 1.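

In this assay, among these compounds, the trifluoromethyl step is the first at this position that lies beyond the scatter, a 2.1-fold lower number from compound 2 to compound 4 (0.32 log units; beyond the scatter), though it is modest, whereas the chloro step, a 1.1-fold lower number from compound 2 to compound 3 (0.03 log units; within the scatter), stays within it. The direct change from 3-chlorophenyl to 4-(trifluoromethyl)phenyl, a 2.0-fold lower number from compound 3 to compound 4 (0.29 log units; within the scatter), remains within the scatter, so these two compounds are not separated in this assay. Nothing available bears on why the trifluoromethyl step reaches beyond the scatter.

That direct change alters both the group and where it sits, and the compounds shown do not separate these two effects. Also open, from the compounds shown here alone, is how this position responds to an amine or a carboxylic acid on the same aromatic ring.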